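Thioether Dopamine Transporter Ligands: Trifluoromethylphenyl to Indole

The compounds below may be only part of what the source reports. "The series", "measured", "known", "first", "only" and "open" are said of these compounds alone.

Compound 2 `Fc1ccc(C(SCCNC2CCN(Cc3ccc(C(F)(F)F)cc3)CC2)c2ccc(F)cc2)cc1` stands at the top of the two numbers measured in an assay on membranes from striatum (strain Sprague-Dawley) for displacement of a labelled ligand from sodium-dependent dopamine transporter (Rattus norvegicus), read by scintillation counting, with a stated time of 120 min; on this read-out higher numbers stand for weaker inhibition and lower numbers for stronger inhibition: compound 2 gives 190 nM. Within the data shown here, its only neighbour, compound 1 `Fc1ccc(C(SCCNC2CCN(Cc3ccc(Cl)cc3)CC2)c2ccc(F)cc2)cc1`, gives 39.6 nM in this assay. Among the measured compounds shown here, the one measured step, a 4.8-fold higher number from compound 1 to compound 2 (0.68 log units; beyond the scatter), shows that the group on that aromatic carbon shifts the read-out by a modest amount.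

Compound 3 `Fc1ccc(C(SCCNC2CCN(Cc3cc4ccccc4[nH]3)CC2)c2ccc(F)cc2)cc1` carries a different change: 1H-indol-2-yl in place of 4-(trifluoromethyl)phenyl on a saturated chain carbon bound to an amine nitrogen in a ring. For the measured compounds named here, no measured step covers an exchange of this kind, so the step from compound 1 to compound 2 serves only as a guide to how far this part of the molecule can move the number. On that basis a step of similar size, towards a lower number, is expected, written as a 2.1-fold lower number from compound 2 to compound 3 (0.32 log units; beyond the scatter). Compound 3 is therefore estimated at 90 nM in this assay, with a range from 25 nM to 350 nM.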

Compound 3, inhibition constant: 179 nM
Beside the measured number, compound 3's estimate is 2.0-fold (0.30 log units) below it; low and high end bracket the measured number.
By their numbers in this assay, from the lowest: compound 1; then compounds 3 and 2 (each within the scatter of the next).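

In this assay the exchange of the whole aromatic group gives a 1.1-fold lower number from compound 2 to compound 3 (0.03 log units; within the scatter) and so leaves the number within the scatter: at this place on a saturated chain carbon bound to an amine nitrogen in a ring, 1H-indol-2-yl and 4-(trifluoromethyl)phenyl cannot be told apart. The same 1H-indol-2-yl group, set against 4-chlorophenyl, gives a 4.5-fold higher number from compound 1 to compound 3 (0.66 log units; beyond the scatter) and so falls on the same side of compound 1 as the trifluoromethyl group, leaving 4-chlorophenyl alone among the three groups shown with the lowest number. No measurement on hand bears on this result.

Going by these compounds, it remains open whether the indole hydrogen matters, which a 1-methylindol-2-yl group would test. Also open, on these data alone, is whether a 4-bromophenyl or 3,4-dichlorophenyl group would match or pass 4-chlorophenyl.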